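Changing the fused ring group of compound 2

The source may hold more compounds than are shown below. What is called first, only, known or untested is meant among the compounds shown, and "the series" means these compounds.

In a physicochemical assay for lipophilicity, using the shake flask method, measured as octanol-water partition, at pH 7.4 (a higher number here means a more lipophilic compound, a lower number a more polar compound), compound 1 `CC(=O)N[C@@H]1CCC[C@H](C(=O)Nc2cc(-c3cnn4ccccc34)c(Cl)cn2)C1` gives 3.6 and compound 2 `CC(=O)N[C@@H]1CCC[C@H](C(=O)Nc2cc(-c3cnn4c3CCC4)c(Cl)cn2)C1` gives 2.9 as the lower of the two numbers. Compound 3 `CC(=O)N[C@@H]1CCC[C@H](C(=O)Nc2cc(-c3cnn4c3CN(C)CC4)c(Cl)cn2)C1` differs from compound 2 on an aromatic carbon opposite the ring nitrogen, with a group of 10 heavy atoms (7 carbon, 3 nitrogen; one five-membered aromatic ring with 2 hetero atoms, one six-membered non-aromatic ring with 2 hetero atoms) in place of a group of 8 heavy atoms (6 carbon, 2 nitrogen; one five-membered non-aromatic ring with 1 hetero atom, one five-membered aromatic ring with 2 hetero atoms), on an aromatic carbon as the counted change. Going by the values given here, one measured step bears on this place: a number 0.70 log units lower from compound 1 to compound 2 (beyond the scatter) at the same aromatic carbon, modest and beyond the scatter. Among the compounds with values here, no measured compound carries the six-membered non-aromatic ring with 2 hetero atoms, so this expectation rests on little. A modest downward move is expected, estimated as a number 0.50 log units lower from compound 2 to compound 3 (beyond the scatter) in this assay here. In this assay compound 3 is estimated at 2.4 within 1.9 to 2.9 as the expected range.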

Compound 3, distribution coefficient: 2.1
For compound 3 the middle estimate is 0.30 log units above the measured one, within the range that was stated.
By their numbers in this assay, from the lowest: compound 3; then compound 2; then compound 1.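

At the aromatic carbon opposite the ring nitrogen, the reading in this assay falls further with the six-membered non-aromatic ring with 2 hetero atoms: a number 0.80 log units lower from compound 2 to compound 3 (beyond the scatter), and overall a number 1.50 log units lower from compound 1 to compound 3 (beyond the scatter). The order does not follow group size, as compound 3 carries the largest of the three groups and has the lowest number. Nothing measured here accounts for these steps.

From the compounds shown here alone, whether the extra ring nitrogen or the larger ring matters more remains open. An oxygen in place of that nitrogen, or an acetyl group on it, would help separate the two.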